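This account rests on a few compounds, and the source may have more. Where it says the series, first, only, none or still open, it means among the compounds named here.

Measured so far:
compound 1 `CCCN(c1nc(-c2ccc(Cl)cc2OC)n(C)n1)C(CC)c1ccc(C(F)(F)F)cc1` gives 12 nM
compound 2 `CCCN(CC1CC1)c1nc(-c2ccc(Cl)cc2OC)n(C)n1` gives 2600 nM

In an in vitro assay on Ltk- cells for binding affinity to corticotropin-releasing factor receptor 1 (Homo sapiens) (a lower number here means a stronger inhibitor, a higher number a weaker inhibitor), compound 2 stands at the highest number of the two measured, its nearest neighbour being compound 1 at a far lower number. Compound 3 `CCCN(c1nc(-c2ccc(Cl)cc2OC)n(C)n1)C(CC)c1ccccc1` is unmeasured; it carries 1-phenylpropyl in place of cyclopropylmethyl on a nitrogen on an aromatic ring. Compound 1 carries a related 1-phenylpropyl bearing a trifluoromethyl group on its ring, and its value in this assay is 12 nM. A large step down, well beyond the scatter, is therefore expected from compound 2 to compound 3, a 65-fold lower number from compound 2 to compound 3 (1.81 log units; beyond the scatter). Compound 3 is estimated at 40 nM, with a range of 10 nM to 160 nM.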

Compound 3, inhibition constant: 26 nM
The estimate for compound 3 lay 1.5-fold (0.19 log units) above the measured number, within the range that was stated.
By their numbers in this assay, from the lowest: compound 1; then compound 3; then compound 2.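

In this assay, 1-phenylpropyl in place of cyclopropylmethyl on the nitrogen gives a 100-fold lower number from compound 2 to compound 3 (2.00 log units; beyond the scatter), so this large step occurs without any trifluoromethyl group on the ring. Hydrogen in place of trifluoromethyl gives a much smaller change, a 2.2-fold higher number from compound 1 to compound 3 (0.34 log units; beyond the scatter). No measurement shown here explains either step.

On these data alone, it remains open whether a saturated cyclohexyl ring could replace the phenyl ring of 1-phenylpropyl. As far as these compounds go, the effect of a nitrile or a fluorine in place of trifluoromethyl also remains open.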